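The source may hold more compounds than are shown below. What is called first, only, known or untested is meant among the compounds shown, and "the series" means these compounds.

Series notes. Compound 1 `O=C(NO)c1ccc(NCc2nc(-c3ccc(Cl)cc3)nn2-c2ccccc2)cc1` gives 67.2% in an assay on Sf9 cells for inhibition of protein deacetylase HDAC6 (Homo sapiens), read by fluorescence, with a stated time of 40 min, tested at 100 nM; a higher number here means more inhibition at the concentration tested (going by the name of the read-out), a lower number less inhibition. Compound 2 `O=C(NO)c1ccc(NCc2nc(-c3ccc(C(F)(F)F)cc3)nn2-c2ccccc2)cc1` carries the change trifluoromethyl in place of chloro on an aromatic carbon and gives 41.6% in this assay; the step of a number 25.6 percentage points lower from compound 1 to compound 2 (beyond the scatter) is the only measured step for this change among the compounds shown. Compound 3 `O=C(NO)c1ccc(NCc2nc(-c3ccccc3)nn2-c2ccc(Cl)cc2)cc1` is built from the same atoms as compound 1 joined differently; the difference between the two cores is not broken down here. In this assay compound 3 gives 55.4%, lower than the value of compound 1 and higher than that of compound 2, both gaps being beyond the scatter.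

Compound 4 `O=C(NO)c1ccc(NCc2nc(-c3ccccc3)nn2-c2ccc(C(F)(F)F)cc2)cc1` is not yet measured. It differs from compound 3 by trifluoromethyl in place of chloro on an aromatic carbon, and the description of where the change sits reads the same word for word as for the step from compound 1 to compound 2, so it is taken as the same change. Among the four compounds it occurs twice in all, once measured. Going by the values given here, the one measured instance of this change is a number 25.6 percentage points lower from compound 1 to compound 2 (beyond the scatter). On that basis a step of a number 23.4 percentage points lower from compound 3 to compound 4 (beyond the scatter) in this assay is expected, close to the measured one. The expectation rests on a single step and on two cores whose difference is not broken down, so the range is kept wide. Compound 4 is estimated at 32% in this assay, with a range from 14% to 52%.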

Compound 4, a percentage reported as inhibition, at one concentration (the size of the read-out at that concentration, not a potency): 38.9%
The estimate for compound 4 lay 6.9 percentage points below the measured number, and the stated range covers the measured number.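

In this assay, trifluoromethyl in place of chloro on an aromatic carbon gives a number 16.5 percentage points lower from compound 3 to compound 4 (beyond the scatter), so the number falls on the core of compound 3 as it did on the core of compound 1. Going by these compounds alone, on these two cores the change carries over in direction, and the two step sizes cannot be told apart: the same change on two cores in this assay, a number 25.6 percentage points lower (beyond the scatter) from compound 1 to compound 2 and a number 16.5 percentage points lower (beyond the scatter) from compound 3 to compound 4, 9.1 percentage points apart, within the scatter of two such steps This rests on only two pairs, each read at a single concentration, so it gives no potency shift, does not break down the difference between the two cores, and does not show that the change would behave alike on any further core.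

Still open, from the compounds shown here alone, is how a nitrile, a methoxy group, an amine or plain hydrogen on the same aromatic carbon would compare with chloro and trifluoromethyl on either core. Also open is whether the same drop would appear in a full concentration series or on another deacetylase, as the compounds shown speak only to this one enzyme at this one concentration.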